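A few compounds are considered here, and "the series" means these few. Any claim that something is new, unique, unknown or untested is made for them only; others in the source may bear on it.

Compound 1 `Cc1cccc(Cl)c1NC(=O)CN1CCN(c2nnc(Cc3ccncc3)c3ccccc23)CC1` gives 7190 nM in a functional assay on A549 cells (Homo sapiens) for cytotoxicity, read by MTT assay, with a stated time of 72 h; a higher number here means a weaker inhibitor, a lower number a stronger inhibitor.
Compound 2 `O=C(CN1CCN(c2nnc(Cc3ccncc3)c3ccccc23)CC1)Nc1ccc(F)c(Cl)c1` gives 12300 nM in this assay.
Compound 3 `Cc1ccccc1NC(=O)CN1CCN(c2nnc(Cc3ccncc3)c3ccccc23)CC1` gives 43100 nM in this assay.

Of the three measured compounds, compound 3 stands with the highest number in this assay. Compound 2 lies nearest to it, with a gap of a 3.5-fold higher number from compound 2 to compound 3 (0.54 log units; beyond the scatter), and compound 1 lies furthest, with a gap of a 6.0-fold higher number from compound 1 to compound 3 (0.78 log units; beyond the scatter); both gaps are beyond the scatter. The two compounds bearing halogenated phenyl groups, compound 1 and compound 2, sit within the scatter of each other, as a 1.7-fold higher number from compound 1 to compound 2 (0.23 log units; within the scatter) shows.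

Compound 4 `O=C(CN1CCN(c2nnc(Cc3ccncc3)c3ccccc23)CC1)Nc1cc(C(F)(F)F)ccc1Cl` differs from compound 3 in one place: 2-chloro-5-(trifluoromethyl)phenyl in place of 2-methylphenyl on an amide-type nitrogen. Going by the values given here, the steps that bear on this change run in the opposite direction: compound 1 to compound 3 removes a chloro group and gives a 6.0-fold higher number from compound 1 to compound 3 (0.78 log units; beyond the scatter), and compound 2 to compound 3 swaps a halogenated phenyl for 2-methylphenyl and gives a 3.5-fold higher number from compound 2 to compound 3 (0.54 log units; beyond the scatter). Returning to a chlorinated phenyl group in compound 4 is therefore expected to bring a modest step downward in this assay, of about a 4.8-fold lower number from compound 3 to compound 4 (0.68 log units; beyond the scatter), so that compound 4 is estimated to fall near the values of compound 1 and compound 2. Compound 4 is thus expected to give 9000 nM, with a likely range from 3500 nM to 25000 nM.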

Compound 4, half-maximal inhibitory concentration: 1850 nM
Compound 4: middle estimate off by 4.9-fold (0.69 log units), on the high side; measured number outside the range, below it.
By their numbers in this assay, from the lowest: compound 4; then compounds 1 and 2 (each within the scatter of the next); then compound 3.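

Going by these compounds alone, at the amide-type nitrogen, the choice of phenyl group moves the number in this assay further than the earlier compounds showed: 2-chloro-5-(trifluoromethyl)phenyl in place of 2-methylphenyl gives a 23-fold lower number from compound 3 to compound 4 (1.37 log units; beyond the scatter) as a large step, where the earlier steps at this place were modest at most. Compound 4 also stands apart from both earlier chlorinated compounds, with a 6.6-fold lower number from compound 2 to compound 4 (0.82 log units; beyond the scatter) and a 3.9-fold lower number from compound 1 to compound 4 (0.59 log units; beyond the scatter) printed as modest steps beyond the scatter, so a chloro group on the phenyl ring does not by itself set the number, and compound 4 has the lowest number of the four. The data shown offer no measurement that accounts for these steps.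

The compounds shown do not separate the share of the chloro group from that of the trifluoromethyl group in 2-chloro-5-(trifluoromethyl)phenyl, as none carries the trifluoromethyl group alone. Going by these compounds, it also stays open whether a nitrile, a methoxy group or an amine in the place of the trifluoromethyl group would keep the number near that of compound 4, and whether the step holds on any core other than the shared one.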